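Fluoro on the Phenyl of a Truncated Nucleoside Analogue

The source may report more compounds than this note shows. Statements on the series, on what has been measured and on what is new or still open speak of the compounds shown alone.

Compound 1 `Nc1ncnn2c([C@@H]3O[C@H](CO)[C@@H](O)[C@H]3O)cc(C#Cc3ccc(F)cc3)c12`: > 100000 nM
Compound 2 `Nc1ncnn2c([C@@H]3O[C@H](CO)[C@@H](O)[C@H]3O)cc(C#Cc3ccccc3)c12`: 46900 nM
Compound 3 `Nc1ncnn2c([C@@H]3O[C@H](CO)[C@@H](O)[C@H]3O)cc(-c3ccccc3)c12`: 82600 nM

Of the compounds shown here, three sharing one core have been measured in a functional assay on HCT-116 cells (Homo sapiens) for antiproliferative activity, with a stated time of 72 h; a higher number here means a weaker inhibitor, a lower number a stronger inhibitor. Compound 2 gives 46900 nM. Compound 3 gives 82600 nM. For compound 1 the value of > 100000 nM is only a limit of the assay, not a number (the limit of > 100000 nM in this assay, at which 1 of the 3 values shown sits).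

The cores of compound 2 and compound 3 differ in one group (phenyl in place of 2-phenylethynyl on an aromatic carbon); the step of a 1.8-fold higher number from compound 2 to compound 3 (0.25 log units; within the scatter) is small.

Compound 4 `Nc1ncnn2c([C@@H]3O[C@H](CO)[C@@H](O)[C@H]3O)cc(-c3ccc(F)cc3)c12` has not yet been measured. It differs from compound 3 by one change (fluoro in place of hydrogen on an aromatic carbon). The same change, at the same kind of place, has already been made from compound 2 to compound 1 (fluoro in place of hydrogen on an aromatic carbon); there it brought an at least 2.1-fold higher number from compound 2 to compound 1 (0.32 log units; beyond the scatter), and since compound 1 gives a limit, the true step may be larger still. Because the step of an at least 2.1-fold higher number from compound 2 to compound 1 (0.32 log units; beyond the scatter) was measured on a close analogue, compound 4 is expected to follow compound 3 in the same direction, a 1.9-fold higher number from compound 3 to compound 4 (0.29 log units; within the scatter), with a real chance that only a limit is reported. In this assay compound 4 is estimated at 160000 nM, within a range from 70000 nM to 400000 nM.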

Compound 4, half-maximal inhibitory concentration: 42500 nM
Beside the measured number, compound 4's estimate is 3.8-fold (0.58 log units) above it; the measured number lies below the stated range.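

In this assay the fluoro change on the phenyl group brings a 1.9-fold lower number from compound 3 to compound 4 (0.29 log units; within the scatter), and this step does not repeat the one seen on the core carrying the 2-phenylethynyl group: the same change on two cores in this assay, an at least 2.1-fold higher number (0.32 log units; beyond the scatter) from compound 2 to compound 1 and a 1.9-fold lower number (0.29 log units; within the scatter) from compound 3 to compound 4, at least 4.1-fold (0.61 log units) apart, beyond the scatter of two such steps Putting 4-fluorophenyl in place of 2-phenylethynyl brings a 1.1-fold lower number from compound 2 to compound 4 (0.04 log units; within the scatter), which cannot be told from repeat measurement, whereas putting it in place of 2-(4-fluorophenyl)ethynyl brings an at least 2.3-fold lower number from compound 1 to compound 4 (0.37 log units; beyond the scatter), a step beyond the scatter whose printed size is only a floor. The fluoro step therefore did not carry over unchanged between these two cores, but a single pair on each core establishes no rule, gives no cause, and leaves the size of the earlier step open, as compound 1 is recorded only as a limit of the assay.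

The compounds shown leave open whether a chloro, a methoxy or an amine in place of the fluoro on the phenyl ring would track the pair of compound 3 and compound 4 or the pair of compound 2 and compound 1. They also leave open how a longer chain in place of the 2-phenylethynyl group would respond to the same fluoro change.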